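The source may report more compounds than this note shows. Statements on the series, on what has been measured and on what is new or still open speak of the compounds shown alone.

The compounds here are tested in a functional assay with metabotropic glutamate receptor 5 (Homo sapiens) as the target, read by FLIPR; a higher number here means a weaker inhibitor, a lower number a stronger inhibitor. Among the measured compounds shown here, compound 1, `CCC(O)(CO)c1cc(F)cc(OCC#Cc2ccccn2)c1`, is the one measured compound with a number: in this assay compound 1 gives 300 nM. Compound 2, `COc1cccc(OCC#Cc2ccncc2)c1`, reaches no number in this assay, only the limit > 10000 nM. Compound 3, `Cc1cccc(C#CCOc2ccccc2)n1`, likewise reaches no number in this assay, only the limit > 10000 nM. So compound 3 stands at the limit of > 10000 nM in this assay, at which 2 of the 3 values shown sit, and nothing further about its strength is known.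

Compound 4, `Cc1cccc(C#CCOc2ccccc2Cl)n1`, is not yet measured. Its change from compound 3 is chloro in place of hydrogen on an aromatic carbon. For the measured compounds named here, since compound 3 is known only as a limit, no measured step gives a guide to the size of this change, and compound 1 and compound 2 differ from compound 3 in more than one place. The expectation is therefore that the step of an at least 1.2-fold lower number from compound 3 to compound 4 (0.09 log units; that floor lies within the scatter) stays small, likely within the scatter, with a fair chance that compound 4 again returns only a limit. Compound 4 is estimated at 8000 nM in this assay, in a range from 2000 nM to 30000 nM.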

Compound 4, half-maximal inhibitory concentration: > 3000 nM
Compound 4 was reported as a limit; the forecaster's own chance of this, stated with the estimate: 60%; the middle value does not contradict the limit.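

Among the compounds shown here, compound 3 and compound 4 are both reported only as limits in this assay, so no step between them can be read. The compounds shown leave open how strong either compound is, and whether chloro in place of hydrogen on an aromatic carbon changes inhibition here.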